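The source may hold more compounds than are shown below. What is called first, only, known or untested is meant among the compounds shown, and "the series" means these compounds.

The measured compounds, all sharing one core and differing only in the acyl group on the oxygen of the side chain:

Compound 1, `CC(C)=CC[C@@H](OC(=O)CCO)C1=CC(=O)c2c(O)ccc(O)c2C1=O`, gives 55300 nM in a functional assay on DU-145 cells (Homo sapiens) for cytotoxicity, read by MTT assay; a higher number here means a weaker inhibitor, a lower number a stronger inhibitor.
Compound 2, `CC(C)=CC[C@@H](OC(=O)CC(O)c1ccccc1)C1=CC(=O)c2c(O)ccc(O)c2C1=O`, gives 17000 nM in this assay.
Compound 3, `CC(C)=CC[C@@H](OC(=O)C1CCCO1)C1=CC(=O)c2c(O)ccc(O)c2C1=O`, gives 10500 nM in this assay.

Compound 2 stands second highest of the three numbers. Its nearest neighbour is compound 3, reached by a 1.6-fold lower number from compound 2 to compound 3 (0.21 log units; within the scatter), a step that stays within the scatter. Its furthest neighbour is compound 1, from which compound 2 is reached by a 3.3-fold lower number from compound 1 to compound 2 (0.51 log units; beyond the scatter), a step beyond the scatter.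

Compound 4, `CC(C)=CC[C@@H](OC(=O)C1CCCOC1)C1=CC(=O)c2c(O)ccc(O)c2C1=O`, differs from compound 2 in one place: oxan-3-yl in place of 2-hydroxy-2-phenylethyl on a carbonyl carbon. Among the measured compounds shown here, the step that bears most directly on this change is the one from compound 2 to compound 3, where another saturated oxygen-containing ring replaced the same 2-hydroxy-2-phenylethyl group and gave a 1.6-fold lower number from compound 2 to compound 3 (0.21 log units; within the scatter). The step of a 5.3-fold lower number from compound 1 to compound 3 (0.72 log units; beyond the scatter) shows that such a ring on the carbonyl carbon sits at the lower end of the numbers seen so far. Compound 4 is therefore expected to land close to compound 3, with a small downward step from compound 2 that does not clear the scatter, a 1.5-fold lower number from compound 2 to compound 4 (0.19 log units; within the scatter) in this assay. For compound 4 the estimate in this assay is 11000 nM, with a range from 5000 nM to 25000 nM.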

Compound 4, half-maximal inhibitory concentration: 29700 nM
Compound 4: the middle estimate sits 2.7-fold (0.43 log units) below what was measured; the measured number lies above the stated range.
By their numbers in this assay, from the lowest: compounds 3, 2, 4 and 1 (each within the scatter of the next, the first and the last beyond it).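

In this assay, among the compounds shown here, the change from oxolan-2-yl to oxan-3-yl on the carbonyl carbon gives a 2.8-fold higher number from compound 3 to compound 4 (0.45 log units; beyond the scatter) and so shows that two saturated rings with one oxygen do not read alike at this place, something the earlier compounds, with only one such ring, could not show. The oxan-3-yl group stays close to both open-chain groups, with a 1.7-fold higher number from compound 2 to compound 4 (0.24 log units; within the scatter) and a 1.9-fold lower number from compound 1 to compound 4 (0.27 log units; within the scatter) both printed as within the scatter, even though a 5.3-fold lower number from compound 1 to compound 3 (0.72 log units; beyond the scatter) had set the oxolan-2-yl ring clearly apart from the 2-hydroxyethyl group. Nothing available accounts for the gap between the two rings.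

The two rings differ in both ring size and point of attachment, so the compounds shown leave open which of these matters. They also leave open how an amine, a carboxylic acid or a longer chain on the same carbonyl carbon would read in this assay against these rings and open-chain groups.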